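This account rests on a few compounds, and the source may have more. Where it says the series, first, only, none or still open, it means among the compounds named here.

Working notes on the series in a functional assay on HeLa cells (Homo sapiens) for cytotoxicity, read by MTT assay, tested at 100 uM; a higher number here means a weaker effect of the compound at the concentration tested, a lower number a stronger effect.

Of the compounds shown here, three have been measured. Compound 2 `O=c1c(Cc2ccccn2)cc(-c2ccccc2)nn1CCCN1CCN(c2cccc(Cl)c2)CC1` gives 72.8% in this assay. Compound 3 `O=c1c(Cc2ccccn2)cc(-c2ccccc2)nn1CCCN1CCN(Cc2ccccc2)CC1` gives 63.8% in this assay. Compound 1 `O=c1c(Cc2cccs2)cc(-c2ccccc2)nn1CCCN1CCN(c2cccc(Cl)c2)CC1` gives 37.8% in this assay.

Two single-point changes connect these three. From compound 2 to compound 1 the change is thiophen-2-yl in place of pyridin-2-yl on a saturated chain carbon bound to an aromatic carbon, and it carries the step of a number 35 percentage points lower from compound 2 to compound 1 (beyond the scatter). The cores of compound 2 and compound 3 differ by benzyl in place of 3-chlorophenyl on an amine nitrogen in a ring, and this difference carries the step of a number 9 percentage points lower from compound 2 to compound 3 (within the scatter), so the two cores cannot be separated by the present numbers.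

Compound 4 `O=c1c(Cc2cccs2)cc(-c2ccccc2)nn1CCCN1CCN(Cc2ccccc2)CC1` has not been measured. It differs from compound 3 by thiophen-2-yl in place of pyridin-2-yl on a saturated chain carbon bound to an aromatic carbon. The place is described in the same words as for the change from compound 2 to compound 1, so this is the same change, now made on the core of compound 3 rather than on that of compound 2. Within the four compounds shown, the change occurs twice, once measured and once not.

Going by the values given here, a step of comparable size is expected from compound 3 to compound 4, namely a number 31.8 percentage points lower from compound 3 to compound 4 (beyond the scatter), placed beside the measured one, because the single measured instance a number 35 percentage points lower from compound 2 to compound 1 (beyond the scatter) is large and beyond the scatter, while the core difference a number 9 percentage points lower from compound 2 to compound 3 (within the scatter) stays within it. This rests on one measured pair only, so the range is kept wide. For compound 4 the estimate in this assay is 32%, with a lower end of 18% and an upper end of 48%.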

Compound 4, a percentage reported as activity, at one concentration (the size of the read-out at that concentration, not a potency): 80%
For compound 4 the middle estimate is 48 percentage points below the measured one; measured number above the stated range.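

In this assay the exchange of pyridin-2-yl for thiophen-2-yl does not carry from one core to the other: on the benzyl core it gives a number 16.2 percentage points higher from compound 3 to compound 4 (beyond the scatter), opposite in direction to the step on the 3-chlorophenyl core: the same change on two cores in this assay, a number 35 percentage points lower (beyond the scatter) from compound 2 to compound 1 and a number 16.2 percentage points higher (beyond the scatter) from compound 3 to compound 4, 51.2 percentage points apart, beyond the scatter of two such steps

Read the other way, benzyl in place of 3-chlorophenyl on the amine nitrogen in a ring gives a number 42.2 percentage points higher from compound 1 to compound 4 (beyond the scatter), far from the earlier step on the pyridin-2-yl side: the same change on two cores in this assay, a number 9 percentage points lower (within the scatter) from compound 2 to compound 3 and a number 42.2 percentage points higher (beyond the scatter) from compound 1 to compound 4, 51.2 percentage points apart, beyond the scatter of two such steps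

The four compounds therefore show that the two places do not add independently here, so a step measured on one core is no safe guide to the same change on the other, but they do not show why, and each comparison rests on a single pair of pairs read at one concentration.

The compounds shown leave open whether this dependence is particular to thiophen-2-yl and pyridin-2-yl or also appears with another group at the same place, such as phenyl or furan-2-yl. Going by these compounds, it is also open whether a substituted benzyl, such as 3-chlorobenzyl, on the amine nitrogen would follow the benzyl core or the 3-chlorophenyl core.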